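Adding a bromine to the benzyl arm of compound 2

This account rests on a few compounds, and the source may have more. Where it says the series, first, only, none or still open, it means among the compounds named here.

Of the compounds shown here, two from this series have been measured in a functional assay on MCF7 cells (Homo sapiens) for inhibition, read by MTT assay, with a stated time of 48 h, tested at 10 uM (a lower number here means less inhibition of growth, a higher number more inhibition of growth at the concentration tested), so far. Compound 1 `C#CCOc1ccc(/C=C/C(=O)c2ccc(OC)cc2)cc1` gives 32%, and compound 2 `O=C(/C=C/c1ccc(OCc2cn(Cc3ccccc3)nn2)cc1)c1ccc(Br)cc1` gives 34%. These two numbers lie within the usual scatter of each other, so the data show no real difference between compound 1 and compound 2 in this assay, and neither can be called the stronger one.

Compound 3 `O=C(/C=C/c1ccc(OCc2cn(Cc3ccc(Br)cc3)nn2)cc1)c1ccc(Br)cc1` has not yet been measured in this assay. It differs from compound 2 in a single place: bromo in place of hydrogen on an aromatic carbon. For the measured compounds named here, no measured pair in this set shows what such an exchange does, so there is no comparable step to lean on.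

Because compound 1 gives 32% and compound 2 gives 34%, two numbers that sit within the scatter of each other despite quite different substituents, a change this small is expected to move the number little. The step of a number 4 percentage points higher from compound 2 to compound 3 (within the scatter) is expected to stay within the usual scatter, with no clear direction. Compound 3 is therefore estimated at 38%, with a plausible range from 22% to 55%.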

Compound 3, percent growth inhibition at one concentration: 23%
For compound 3 the middle estimate is 15 percentage points above the measured one; measured number inside the range.
By their numbers in this assay, from the lowest: compounds 3, 1 and 2 (each within the scatter of the next, the first and the last beyond it).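

For the compounds shown here, compound 3 supplies the first comparison that changes only one place, turning benzyl into 4-bromobenzyl on the arm attached to the triazole. In this assay, this single exchange of hydrogen for bromo gives a number 11 percentage points lower from compound 2 to compound 3 (beyond the scatter), so this aromatic carbon, para to a large group, is not a place where any change passes unnoticed, although the step is modest and rests on one pair of compounds. The data given offer no explanation for why growth inhibition falls with this exchange.

The compounds shown leave open whether this fall belongs to bromine itself or would follow any group placed on the same carbon, a question that fluoro, methoxy or an amine there could help to answer. From the compounds shown here alone, it also remains open whether the bromo on the other aromatic ring, shared by compound 2 and compound 3, has any bearing on the step, since a matching pair with hydrogen in its place would be needed to show this.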